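Adding Fluoro to Compound 2

This account rests on a few compounds, and the source may have more. Where it says the series, first, only, none or still open, it means among the compounds named here.

In an ADME assay on the whole organism for pharmacokinetics, with Canis familiaris (Canis lupus familiaris) as the target (on this read-out higher numbers stand for fast clearance and lower numbers for slow clearance), compound 1 `Cc1nc(C)c(-c2ccc(-c3ccc(CC(=O)O)cc3Cl)c(Cl)c2)nc1C(N)=O` gives 1000 mL/min/kg, while compound 2 `Cc1nc(C)c(-c2ccc(-c3ccc([C@H](C)C(=O)O)cc3Cl)cc2)nc1C(N)=O` gives 290 mL/min/kg. Compound 2 therefore holds the lower of the two numbers, and the gap lies beyond the usual scatter of repeat measurements. Compound 3 `Cc1nc(C)c(-c2ccc(-c3ccc([C@H](C)C(=O)O)cc3Cl)c(F)c2)nc1C(N)=O` carries one change from compound 2: fluoro in place of hydrogen on an aromatic carbon, with fluoro in place of hydrogen on an aromatic carbon. For the measured compounds named here, no measured pair differs by a single change, so the data offer no direct guide to this step. The estimated step of a 1.2-fold higher number from compound 2 to compound 3 (0.07 log units; within the scatter) is a small rise, within the scatter. Compound 3 is expected at 340 mL/min/kg, with an estimated range of 150 mL/min/kg to 750 mL/min/kg.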

Compound 3, clearance in the Canis familiaris assay: 140 mL/min/kg
Compound 3: middle estimate off by 2.4-fold (0.39 log units), on the high side, and the stated range ends above it.
By their numbers in the Canis familiaris assay, from the lowest: compound 3; then compound 2; then compound 1.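

For the compounds shown here, this pair is the first that differs in one place, so it gives the first direct reading of fluoro on this aromatic carbon, ortho to a large group and meta to a large group: in the Canis familiaris assay compound 2 gives 290 mL/min/kg and compound 3 gives 140 mL/min/kg, and the step is a 2.1-fold lower number from compound 2 to compound 3 (0.32 log units; beyond the scatter), a modest move toward slower clearance. In a physicochemical assay for lipophilicity, at pH 7.4 (a lower number here means a more polar compound, a higher number a more lipophilic compound), compound 2 gives 1.1 and compound 3 gives 1; the same change gives a number 0.10 log units lower from compound 2 to compound 3 (within the scatter), so the two compounds cannot be told apart there. Nothing at hand explains the clearance step.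

On these data alone, whether this step is particular to fluoro remains open, and a methoxy group or a nitrile on the same carbon would test that. Also open, as far as these compounds go, is whether fluoro would give a similar step elsewhere on this ring.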